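A Single Swap at the Amine of a Kinase-Type Core

A few compounds are considered here, and "the series" means these few. Any claim that something is new, unique, unknown or untested is made for them only; others in the source may bear on it.

Of the compounds shown here, two have been measured in a functional assay on K562 cells (Homo sapiens) for inhibition, read by trypan blue exclusion, with a stated time of 72 h; a lower number here means a stronger inhibitor, a higher number a weaker inhibitor. Compound 1, `CCCn1c(=O)c(S(=O)(=O)c2ccc(F)cc2F)cc2cnc(Nc3ccc4[nH]ccc4c3)nc21`, gives 1000 nM in this assay. Compound 2, `Cn1c(=O)c(S(=O)(=O)c2ccc(F)cc2F)cc2cnc(Nc3ccc4sccc4c3)nc21`, gives 500 nM in this assay. Compound 2 carries the lower of the two numbers, but the gap to compound 1 lies within the usual scatter of repeated measurements, so the two compounds cannot be told apart on these data alone.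

Compound 3, `Cn1c(=O)c(S(=O)(=O)c2ccc(F)cc2F)cc2cnc(Nc3ccc4[nH]ncc4c3)nc21`, has not yet been measured. It differs from compound 2 in one place: 1H-indazol-5-yl in place of 1-benzothiophen-5-yl on a nitrogen on an aromatic ring. Among the measured compounds shown here, no pair of measured compounds differing in exactly one place is available, so no measured step can guide the expectation. The change keeps the size of the group and adds one hydrogen-bond donor while the acceptor count stays the same.

For the measured compounds named here, with no measured step to rest on, compound 3 is expected to give a value that sits close to compound 2, with the step from compound 2 to compound 3 estimated at a 1.2-fold higher number from compound 2 to compound 3 (0.08 log units; within the scatter), not clearly beyond the scatter in either direction. The estimate for compound 3 in this assay is 600 nM, with a range from 200 nM to 2000 nM.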

Compound 3, half-maximal inhibitory concentration: 50000 nM
Beside the measured number, compound 3's estimate is 83-fold (1.92 log units) below it; the whole stated range lies below it.
By their numbers in this assay, from the lowest: compounds 2 and 1 (each within the scatter of the next); then compound 3.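

In this assay, the group on a nitrogen on an aromatic ring proves to matter greatly: replacing 1-benzothiophen-5-yl with 1H-indazol-5-yl, with the rest of the molecule unchanged, gives a 100-fold higher number from compound 2 to compound 3 (2.00 log units; beyond the scatter), a large step well beyond the scatter. Both groups have 9 heavy atoms and the same ring sizes, so in this pair a matching heavy-atom count and matching ring sizes do not keep the number in place; the counted differences are that sulfur and one carbon give way to 2 nitrogens, and that 1H-indazol-5-yl carries 1 hydrogen-bond donor where 1-benzothiophen-5-yl carries 0. Nothing measured here gives a reason for the size of this step.

On these data alone, it remains open whether the step follows the hydrogen on the indazole nitrogen or the ring nitrogens themselves: a 1-methyl-1H-indazol-5-yl group and a 1-benzofuran-5-yl group in the same place would help to separate the two. Compound 1 differs from compound 3 in more than one place, so it cannot settle this question.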